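From benzyloxy to pentyloxy: a cytotoxicity step

The source may report more compounds than this note shows. Statements on the series, on what has been measured and on what is new or still open speak of the compounds shown alone.

The account starts from compound 1 `Nc1nc(OCc2ccccc2)c2ncn(/C=C3/CC3(CO)CO)c2n1`. In an ADME assay on Akata cells (Homo sapiens) for cytotoxicity, with a stated time of 7 days (a higher number here means that more compound is tolerated, a lower number that less compound is tolerated), compound 1 gives > 20000 nM, which is a limit of the assay and not a number. Compound 2 `CCCSc1nc(N)nc2c1ncn2/C=C1/CC1(CO)CO` likewise reaches only a limit, at > 20000 nM. Compound 3 `CCCCCCSc1nc(N)nc2c1ncn2/C=C1/CC1(CO)CO` also stops at a limit, > 20000 nM. The steps a step that the two limits leave unreadable from compound 1 to compound 2, a step that the two limits leave unreadable from compound 1 to compound 3 and a step that the two limits leave unreadable from compound 2 to compound 3 are therefore not readable; all three values sit at the limit of > 20000 nM in this assay, at which 3 of the 3 values shown sit. Compound 4 `CCCCCOc1nc(N)nc2c1ncn2/C=C1/CC1(CO)CO` differs from compound 1 by butyl in place of phenyl on a saturated chain carbon bound to an oxygen on an aromatic ring. Within the data shown here, no measured step gives a readable size or direction, so the only expectation is that the step that the limit leaves unreadable from compound 1 to compound 4 stays inside the limit. Compound 4 is estimated at 30000 nM, between 15000 nM and 80000 nM.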

Compound 4, half-maximal cytotoxic concentration: > 20000 nM
Compound 4 ended at the assay's limit (the forecaster's own chance of this, stated with the estimate: 85%); the middle value does not contradict the limit.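

In this assay compound 4 gives > 20000 nM as a limit of the assay and not a number, so its steps from compounds 1, 2 and 3 cannot be read: the limit of > 20000 nM in this assay, at which 4 of the 4 values shown sit.

From the compounds shown here alone, whether benzyloxy, pentyloxy, propylsulfanyl and hexylsulfanyl differ at all in this assay stays open.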